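Moving the chloropyrimidine attachment point on a longer chain

The compounds below may be only part of what the source reports. "The series", "measured", "known", "first", "only" and "open" are said of these compounds alone.

Compound 1 `Clc1ccc2c(NCCCNc3nccc(Cl)n3)ccnc2c1` gives 0.657 in a physicochemical assay for lipophilicity, read by HPLC, in phosphate buffer, measured as octanol-water partition, with a stated time of 24 h, at pH 7.4; on this read-out higher numbers stand for higher lipophilicity and lower numbers for lower lipophilicity.
Compound 2 `Clc1ccc2c(NCCCNc3ccnc(Cl)n3)ccnc2c1` gives 0.229.
Compound 3 `Clc1ccc2c(NCCCCCCCCNc3nccc(Cl)n3)ccnc2c1` gives 1.51.

Compound 1 and compound 2 share everything except one change, (2-chloropyrimidin-4-yl in place of 4-chloropyrimidin-2-yl on an amine nitrogen). That change made a step of a number 0.43 log units lower from compound 1 to compound 2 (beyond the scatter). Compound 3 carries the same chloropyrimidine as compound 1 but on a different core; how its core differs from the core of compound 1 is not broken down here. Among the three measured compounds, compound 3 stands highest, with compound 1 nearest and compound 2 furthest.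

Compound 4 `Clc1ccc2c(NCCCCCCCCNc3ccnc(Cl)n3)ccnc2c1` is not yet measured. It differs from compound 3 by 2-chloropyrimidin-4-yl in place of 4-chloropyrimidin-2-yl on an amine nitrogen, and the place of the change is described in the same words as for the change from compound 1 to compound 2, so it is the same change made a second time. For the measured compounds named here, the expectation for compound 4 therefore rests on the single measured example, the step of a number 0.43 log units lower from compound 1 to compound 2 (beyond the scatter), applied to compound 3. On that basis, a step of about a number 0.43 log units lower from compound 3 to compound 4 (beyond the scatter) is expected. Compound 4 is estimated at 1.08, with a likely range from 0.7 to 1.45.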

Compound 4, distribution coefficient: 1.48
Compound 4: the middle estimate sits 0.40 log units below what was measured; measured number outside the range, above it.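

On this assay the change to 2-chloropyrimidin-4-yl in place of 4-chloropyrimidin-2-yl on an amine nitrogen gave a number 0.43 log units lower from compound 1 to compound 2 (beyond the scatter) on one core but a number 0.03 log units lower from compound 3 to compound 4 (within the scatter) on the other. So a step measured on one core did not carry over in size to the other, and this pair of examples is enough to warn against treating the change as a fixed correction across these two cores, though it sets no rule for any further core. Nothing measured here bears on why the step was not repeated, and the way the two cores differ has not been broken down, so no explanation can be offered.

The compounds shown leave open how the step would behave on cores with a chain of another length, which would show whether the result on the second core is a single case or part of a trend. They also leave open whether the step would hold with a carboxylic acid or a hydroxyl group on the chain.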